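The source may hold more compounds than are shown below. What is called first, only, known or untested is meant among the compounds shown, and "the series" means these compounds.

Measured in a physicochemical assay for lipophilicity, read by HPLC; a higher number here means a more lipophilic compound, a lower number a more polar compound:
- compound 1 `CC(=O)NC[C@H]1CN(c2ccc(OC[C@@H](O)CNc3ccccn3)c(F)c2)C(=O)O1`: 1.37
- compound 2 `CC(=O)NC[C@H]1CN(c2ccc(OC[C@H](O)CNc3ccccn3)c(F)c2)C(=O)O1`: 1.6
- compound 3 `CC(=O)NC[C@H]1CN(c2ccc(OC[C@@H](O)CNc3cccnc3)c(F)c2)C(=O)O1`: 0.02

Compound 3 stands lowest of the three on this assay. Compound 4 `CC(=O)NC[C@H]1CN(c2ccc(OC[C@H](O)CNc3ccncc3)c(F)c2)C(=O)O1` differs from it by 1-hydroxy-2-((pyridin-4-yl)amino)ethyl in place of 1-hydroxy-2-((pyridin-3-yl)amino)ethyl on a saturated chain carbon bound to an oxygen on an aromatic ring, with 1-hydroxy-2-((pyridin-4-yl)amino)ethyl in place of 1-hydroxy-2-((pyridin-3-yl)amino)ethyl. Among the measured compounds shown here, two measured steps bear on this change, and both are large: a number 1.35 log units lower from compound 1 to compound 3 (beyond the scatter) and a number 1.58 log units lower from compound 2 to compound 3 (beyond the scatter). A change of configuration as drawn gave only a number 0.23 log units higher from compound 1 to compound 2 (within the scatter), within the scatter. Neither large step measures pyridin-4-yl, but both set the pyridin-2-yl compounds apart, so compound 4 is expected to stay near compound 3 at 0.02. The expected step is a number 0.22 log units lower from compound 3 to compound 4 (within the scatter), small and uncertain. For compound 4 the estimated value is -0.2, with an expected range from -0.9 to 0.6.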

Compound 4, partition coefficient: 0.02
For compound 4 the middle estimate is 0.22 log units below the measured one; the range from low to high includes it.
By their numbers in this assay, from the lowest: compounds 3 and 4 (each within the scatter of the next); then compounds 1 and 2 (each within the scatter of the next).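

In this assay, pyridin-4-yl in place of pyridin-3-yl gives no change at the digits printed from compound 3 to compound 4 (within the scatter), so the earlier large drop is not peculiar to pyridin-3-yl. Pyridin-4-yl in place of pyridin-2-yl gives a number 1.58 log units lower from compound 2 to compound 4 (beyond the scatter), and the other pyridin-2-yl pairing gives a number 1.35 log units lower from compound 1 to compound 4 (beyond the scatter), so among these three groups only pyridin-2-yl stands high. Among the compounds shown here, compound 3 and compound 4 also differ in drawn configuration at the chain carbon, and the only pair that isolates such a change stayed within the scatter: the fact that compounds 1 and 2 differ only in the configuration as drawn. Going by these compounds, whether a phenyl ring or a pyrimidin-2-yl group on the amine nitrogen would stand with the pyridin-2-yl compounds or with compound 3 and compound 4 remains open.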